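Azetidine amides and sulfonamides at the mGlu5 receptor

The source may report more compounds than this note shows. Statements on the series, on what has been measured and on what is new or still open speak of the compounds shown alone.

Compound 1 `O=C(N1CCC(F)CC1)N1CC(c2nc(-c3cccc(Cl)c3)no2)C1`: 990 nM
Compound 2 `O=S(=O)(c1ccc(Cl)cc1)N1CC(c2nc(-c3cccc(Cl)c3)no2)C1`: > 10000 nM
Compound 3 `Cc1ccc(S(=O)(=O)N2CC(c3nc(-c4cccc(C)c4)no3)C2)cc1`: > 10000 nM

Three compounds share a core and were tested in an assay on HEK293 cells for positive allosteric modulation of metabotropic glutamate receptor 5 (Homo sapiens), read by FLIPR; a lower number here means that less compound is needed, a higher number that more compound is needed for the effect. Compound 1 gives 990 nM, and it is the only one of the three for which a number is reported. For compound 2 the result is a limit of the assay, > 10000 nM. For compound 3 the result is likewise a limit, > 10000 nM. The two limits are summarised as follows: the limit of > 10000 nM in this assay, at which 2 of the 3 values shown sit. Among the measured compounds shown here, compound 1 therefore stands alone as the only compound with a measured value, and no step between two measured compounds can be sized.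

Compound 4 `O=C([C@@H]1CC2CCC1C2)N1CC(c2nc(-c3cccc(Cl)c3)no2)C1` differs from compound 1 in one place: a group of 7 heavy atoms (7 carbon; 2 five-membered non-aromatic rings of carbon only) in place of a group of 7 heavy atoms (5 carbon, 1 nitrogen, 1 fluorine; one six-membered non-aromatic ring with 1 hetero atom), on a carbonyl carbon. The 4-fluoropiperidin-1-yl group leaves and a group of two five-membered non-aromatic rings of carbon only enters, on the carbonyl carbon whose other neighbour is the amide-type nitrogen in a ring. Without a measured step to rest on, the expected change is modest, within or close to the scatter, with a slight lean toward needing less compound. Compound 4 is expected to give 700 nM, in the range 150 nM to 3000 nM, a step of a 1.4-fold lower number from compound 1 to compound 4 (0.15 log units; within the scatter) from compound 1.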

Compound 4, half-maximal effective concentration: 98 nM
For compound 4 the middle estimate is 7.1-fold (0.85 log units) above the measured one; the whole stated range lies above it.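

Among the compounds shown here, on the carbonyl carbon whose other neighbour is the amide-type nitrogen in a ring, replacing the 4-fluoropiperidin-1-yl group with the carbon-only group of two five-membered rings gives a 10-fold lower number from compound 1 to compound 4 (1.00 log units; beyond the scatter) in this assay, the first step here that can be sized. The position therefore responds to the group it carries, even though the two groups have equal heavy-atom counts and neither has a hydrogen-bond donor or acceptor. No measured property among the compounds shown bears on why the number falls.

Steps to compound 2 and compound 3 cannot be read, as each result is a limit of the assay and not a number: the limit of > 10000 nM in this assay, at which 2 of the 4 values shown sit. Whether a cyclohexyl ring, a tert-butyl group or a morpholine on the same carbonyl carbon would read like compound 4 or like compound 1 remains open.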